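A Second Methoxy Group on the Bromo Analogue

A few compounds are considered here, and "the series" means these few. Any claim that something is new, unique, unknown or untested is made for them only; others in the source may bear on it.

Compound 1 `COc1ccc(C(=O)n2c(-c3cn(C)c4ccccc34)nc3ccccc32)cc1OC`: 3100 nM
Compound 2 `COc1cc(C(=O)n2c(-c3cn(C)c4ccccc34)nc3ccccc32)cc(OC)c1OC`: 2600 nM
Compound 3 `COc1ccc(C(=O)n2c(-c3cn(C)c4ccc(Br)cc34)nc3ccccc32)cc1`: 11300 nM

In a functional assay on A549 cells (Homo sapiens) for inhibition, read by MTT assay, with a stated time of 24 h (on this read-out higher numbers stand for weaker inhibition of growth and lower numbers for stronger inhibition of growth), compound 1 gives 3100 nM and compound 2 gives 2600 nM. The change between them is methoxy in place of hydrogen on an aromatic carbon, and it made a step of a 1.2-fold lower number from compound 1 to compound 2 (0.08 log units; within the scatter). In this assay compound 3 gives 11300 nM; how its core differs from that of compound 1 is not broken down here. Compound 4 `COc1ccc(C(=O)n2c(-c3cn(C)c4ccc(Br)cc34)nc3ccccc32)cc1OC` is not yet measured and differs from compound 3 by methoxy in place of hydrogen on an aromatic carbon. The surroundings are not identical: in compound 1 the place is also meta to a methoxy group, so this is the same kind of change rather than the same one. Because a 1.2-fold lower number from compound 1 to compound 2 (0.08 log units; within the scatter) lay within the scatter, a similarly small step is expected here, a 1.2-fold lower number from compound 3 to compound 4 (0.08 log units; within the scatter). Compound 4 is therefore expected to give about 9500 nM, somewhere between 3500 nM and 25000 nM.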

Compound 4, concentration for 50% growth inhibition: 3400 nM
Compound 4: middle estimate off by 2.8-fold (0.45 log units), on the high side; the measured number lies below the stated range.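

Carrying this change from one core to another in this series does not give a step of fixed size, as this assay shows: the same change on two cores in this assay, a 1.2-fold lower number (0.08 log units; within the scatter) from compound 1 to compound 2 and a 3.3-fold lower number (0.52 log units; beyond the scatter) from compound 3 to compound 4, 2.8-fold (0.45 log units) apart, beyond the scatter of two such steps On the bromo-bearing core, the added methoxy gave a 3.3-fold lower number from compound 3 to compound 4 (0.52 log units; beyond the scatter), while bromo in place of hydrogen gave a 1.1-fold higher number from compound 1 to compound 4 (0.04 log units; within the scatter), so with the 3,4-dimethoxyphenyl group in place, bromo made no readable difference. This is one pair of steps in surroundings that are not identical, so it shows neither why the steps differ nor how other cores would behave.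

From the compounds shown here alone, it remains open how a third methoxy group would act on the bromo-bearing core. An amine or a longer chain such as butoxy in place of the added methoxy is also untested among the compounds shown.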